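This account rests on a few compounds, and the source may have more. Where it says the series, first, only, none or still open, it means among the compounds named here.

Compound 1 `CS(=O)(=O)c1ccccc1NCc1c[nH]cn1`: in a functional assay for activation of Alpha-1D adrenergic receptor (Homo sapiens) (a lower number here means that less compound is needed, a higher number that more compound is needed for the effect), compound 1 gives < 100000 nM, a limit.
Compound 2 `c1ccc(-c2cnco2)c(NCc2c[nH]cn2)c1`: in this assay compound 2 gives < 252 nM, a limit.
Compound 3 `c1ccc(N2CCCCC2)c(NCC2=NCCN2)c1`: in this assay compound 3 gives < 5020 nM, a limit.

Compound 3 stands in this assay only as a limit (the limit of < 5020 nM in this assay, at which 1 of the 3 values shown sits), and the two other values shown are limits as well (the limit of < 100000 nM in this assay, at which 1 of the 3 values shown sits, (the limit of < 252 nM in this assay, at which 1 of the 3 values shown sits)), so no ordering among the three compounds can be read from them. Among the measured compounds shown here, the one step between measured compounds that differ in one place, a step that the two limits leave unreadable from compound 1 to compound 2, is left unreadable by its two limits. Compound 4 `c1ccc(N2CCCCC2)c(NCc2c[nH]cn2)c1` differs from compound 3 by a group of 5 heavy atoms (3 carbon, 2 nitrogen; one five-membered aromatic ring with 2 hetero atoms) in place of a group of 5 heavy atoms (3 carbon, 2 nitrogen; one five-membered non-aromatic ring with 2 hetero atoms), on a saturated chain carbon bound to a nitrogen on an aromatic ring. For the measured compounds named here, no measured step bears on this change directly; compound 2 carries the same 1H-imidazol-4-yl on the same kind of chain carbon, but its value is a limit. The step from compound 3 to compound 4 is therefore expected to be a step that the limit leaves unreadable from compound 3 to compound 4 in this assay, with wide uncertainty. For compound 4 the estimate in this assay is 500 nM, expected to lie between 50 nM and 5000 nM.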

Compound 4, half-maximal effective concentration: < 5020 nM
Compound 4: a limit, no number (the forecaster's own chance of this, stated with the estimate: 50%); the middle value lies beyond the limit too.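

No step to compound 4 from compound 1, compound 2 or compound 3 can be read in this assay, and compound 4 shares its limit with compound 3: the limit of < 5020 nM in this assay, at which 2 of the 4 values shown sit. The compounds shown leave open whether 1H-imidazol-4-yl in compound 4 changes the effective concentration relative to the group it replaces in compound 3.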